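Moving the halogen around the benzamide ring

This account rests on a few compounds, and the source may have more. Where it says the series, first, only, none or still open, it means among the compounds named here.

Compound 1: `O=C(Nc1cc(-c2ccccc2)nn1-c1ccccc1)c1ccc(F)cc1`, 30 nM
Compound 2: `O=C(Nc1cc(-c2ccccc2)nn1-c1ccccc1)c1ccccn1`, 290 nM
Compound 3: `O=C(Nc1cc(-c2ccccc2)nn1-c1ccccc1)c1ccccc1F`, 75 nM

In an assay on CHO cells with metabotropic glutamate receptor 5 (Homo sapiens) as the target (a higher number here means that more compound is needed for the effect, a lower number that less compound is needed), compound 3, `O=C(Nc1cc(-c2ccccc2)nn1-c1ccccc1)c1ccccc1F`, gives 75 nM. Among the three measured compounds it stands second: compound 1 gives 30 nM, and the step of a 2.5-fold higher number from compound 1 to compound 3 (0.40 log units; beyond the scatter) lies beyond the scatter, while compound 2 gives 290 nM, with a 3.9-fold lower number from compound 2 to compound 3 (0.59 log units; beyond the scatter) also beyond the scatter.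

Compound 4, `O=C(Nc1cc(-c2ccccc2)nn1-c1ccccc1)c1ccc(Cl)cc1`, has not yet been measured. It differs from compound 3 by 4-chlorophenyl in place of 2-fluorophenyl on a carbonyl carbon. The step that bears most on this change is a 2.5-fold higher number from compound 1 to compound 3 (0.40 log units; beyond the scatter), which shows that a fluorine at the 4-position of the benzamide ring goes with a lower number than a fluorine at the 2-position. Compound 4 carries its halogen at the same 4-position as compound 1, so a return toward the number of compound 1 is expected, with the chlorine itself of unknown effect here. The expected step is a 2.5-fold lower number from compound 3 to compound 4 (0.40 log units; beyond the scatter). For compound 4 the estimate in this assay is 30 nM, within 10 nM to 90 nM.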

Compound 4, half-maximal effective concentration: 20 nM
Beside the measured number, compound 4's estimate is 1.5-fold (0.18 log units) above it; the measured number falls inside the stated range.
By their numbers in this assay, from the lowest: compounds 4 and 1 (each within the scatter of the next); then compound 3; then compound 2.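

With 4-chlorophenyl on the carbonyl carbon, this assay gives a 1.5-fold lower number from compound 1 to compound 4 (0.18 log units; within the scatter), so chloro in place of fluoro on an aromatic carbon makes no difference that can be told from the scatter. The 4-chlorophenyl group also stands clear of the two other groups at this place: 2-fluorophenyl gives way to it with a 3.8-fold lower number from compound 3 to compound 4 (0.57 log units; beyond the scatter) and pyridin-2-yl with a 15-fold lower number from compound 2 to compound 4 (1.16 log units; beyond the scatter) as the step. Within the data shown here, the low numbers of the set are thus no longer tied to 4-fluorophenyl alone, which the earlier compounds could not show.

On these data alone, what a 4-methoxyphenyl or a 4-aminophenyl group would give on the same carbonyl carbon stays open. So does the number for 2-chlorophenyl, which would show whether chlorine follows fluorine when its place on the ring changes. Nothing at hand accounts for these steps.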